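Replacing 3,5-dichlorophenyl with 3,4-dihydroxyphenyl in the series

The source may report more compounds than this note shows. Statements on the series, on what has been measured and on what is new or still open speak of the compounds shown alone.

In a functional assay on A549 cells (Homo sapiens) for cytotoxicity, read by MTT assay, with a stated time of 72 h (on this read-out lower numbers stand for stronger inhibition and higher numbers for weaker inhibition), compound 1 (`COc1ccc(/C=C2\CCC/C(=C\c3ccc(Cl)cc3)C2=O)cc1OC`) gives 10100 nM and compound 2 (`COc1ccc(/C=C2\CCC/C(=C\c3cc(Cl)cc(Cl)c3)C2=O)cc1OC`) gives 5500 nM. These two values lie within the scatter of each other, so compound 2 has no clear standing apart from compound 1. Among the measured compounds shown here, the only measured step is a 1.8-fold lower number from compound 1 to compound 2 (0.26 log units; within the scatter), a change in the chlorine pattern on the aryl group that stays within the scatter.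

The next structure is compound 3 (`COc1ccc(/C=C2\CCC/C(=C\c3ccc(O)c(O)c3)C2=O)cc1OC`), with 3,4-dihydroxyphenyl in place of 3,5-dichlorophenyl on a double-bonded chain carbon bound to a double-bonded ring carbon. For the measured compounds named here, the measured step bears on this change only in part, as both of its compounds carry chlorine and no hydroxyl-bearing compound has been measured. With that single small step as the guide, no shift beyond the scatter is expected in this assay, and no direction can be supported. The expected change is a 1.1-fold lower number from compound 2 to compound 3 (0.04 log units; within the scatter). Compound 3 is estimated at 5000 nM, with an expected range of 1500 nM to 16000 nM, kept wide for lack of a closer comparison.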

Compound 3, half-maximal inhibitory concentration: > 20000 nM
Compound 3: no number, only a limit; the forecaster's own chance of this, stated with the estimate: 5%; at least 4.0-fold (0.60 log units) between middle value and limit.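

In this assay compound 3 gives > 20000 nM, which is a limit of the assay and not a number: the limit of > 20000 nM in this assay, at which 1 of the 3 values shown sits. The exchange of 3,5-dichlorophenyl for 3,4-dihydroxyphenyl on a double-bonded chain carbon bound to a double-bonded ring carbon gives an at least 3.6-fold higher number from compound 2 to compound 3 (0.56 log units; beyond the scatter), so this place responds to the group it carries in a way that the change in chlorine pattern alone did not show. Among the compounds shown here, the other comparison is less firm, with an at least 1.9-fold higher number from compound 1 to compound 3 (0.29 log units; that floor lies within the scatter), so only the step from the 3,5-dichlorophenyl compound is clear of the scatter.

The limit leaves the full size of the step unread, and the chlorine atoms leave as the hydroxyl groups enter, so the data cannot tell which of the two carries the step. A phenyl with a single hydroxyl group, or one carrying an amine or a carboxylic acid, at this same place would help separate the two and show whether the step is tied to the hydroxyl groups themselves.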